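The source may report more compounds than this note shows. Statements on the series, on what has been measured and on what is new or still open speak of the compounds shown alone.

Compound 1 `CC(=O)N[C@@H](CSC/C=C(\C)CC/C=C(\C)CCC=C(C)C)C(=O)C=[N+]=[N-]` gives 30300 nM in a functional assay on NALM-6 cells (Homo sapiens) (on this read-out higher numbers stand for weaker inhibition and lower numbers for stronger inhibition), the lowest of the two numbers shown there. Compound 2 `CC(C)=CCC/C(C)=C/CC/C(C)=C/CSC[C@H](NC(=O)OC(C)(C)C)C(=O)C=[N+]=[N-]` gives 49800 nM, and a 1.6-fold higher number from compound 1 to compound 2 (0.22 log units; within the scatter). Compound 3 `CC(=O)N[C@@H](CSC/C=C(\C)CCC=C(C)C)C(=O)C=[N+]=[N-]` reaches only the limit of the assay, > 100000 nM (the limit of > 100000 nM in this assay, at which 1 of the 3 values shown sits). The step of an at least 3.3-fold higher number from compound 1 to compound 3 (0.51 log units; beyond the scatter) is the only one beyond the scatter. Compound 4 `CC(=O)N[C@@H](CSC/C=C(\C)CC/C=C(\C)CCC=C(C)C)C(=O)CCl` differs from compound 1 by a group of 2 heavy atoms (1 carbon, 1 chlorine; no ring) in place of a group of 3 heavy atoms (1 carbon, 2 nitrogen; no ring), on a carbonyl carbon. Neither measured step touches that carbonyl carbon, so neither bears directly on this change, and no size of step can be read from them; the author therefore expects a step of a 1.5-fold lower number from compound 1 to compound 4 (0.18 log units; within the scatter), within or near the scatter. For compound 4 the estimate in this assay is 20000 nM, between 5000 nM and 80000 nM.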

Compound 4, half-maximal inhibitory concentration: 3000 nM
Compound 4: middle estimate off by 6.7-fold (0.82 log units), on the high side; measured number below the stated range.
By their numbers in this assay, from the lowest: compound 4; then compounds 1 and 2 (each within the scatter of the next). At a limit, above all of these: compound 3.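

Placing chloromethyl on the carbonyl carbon in this assay gives a 10-fold lower number from compound 1 to compound 4 (1.00 log units; beyond the scatter) and shows that this position can move the number well beyond the scatter. Until now, the only step beyond the scatter went towards a higher number, so this is the first change shown to lower it. Nothing shown explains why this exchange has that effect.

On these data alone, whether bromomethyl or fluoromethyl on this carbonyl carbon would give a similar number remains open. So does whether chloromethyl would have the same effect with the shorter chain of compound 3.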